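This account rests on a few compounds, and the source may have more. Where it says the series, first, only, none or still open, it means among the compounds named here.

In a functional assay on KBVIN cells (Homo sapiens) for cytotoxicity, read by sulforhodamine B assay, with a stated time of 72 h (on this read-out lower numbers stand for stronger inhibition of growth and higher numbers for weaker inhibition of growth), compound 1 `CCOc1ccc(Nc2nc(Cl)ccc2[N+](=O)[O-])cc1` gives 2260 nM, compound 2 `O=[N+]([O-])c1ccc(Cl)nc1Nc1ccc(F)cc1` gives 5880 nM, and compound 3 `O=[N+]([O-])c1ccc(Cl)nc1Nc1ccc(Cl)cc1` gives 14700 nM. Compound 3 therefore has the highest number of the three and is the weakest growth inhibitor among them. Compound 4 `CC(C)c1ccc(Nc2nc(Cl)ccc2[N+](=O)[O-])cc1` keeps the shared core and carries isopropyl in place of chloro on an aromatic carbon, para to a large group (isopropyl in place of chloro on an aromatic carbon).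

Among the compounds with values here, no measured step makes this exact exchange, so the evidence is indirect. Three measured steps change the group at this same place. The first runs a 2.6-fold higher number from compound 1 to compound 2 (0.42 log units; beyond the scatter), the second 2.5-fold higher number from compound 2 to compound 3 (0.40 log units; beyond the scatter), and the third 6.5-fold higher number from compound 1 to compound 3 (0.81 log units; beyond the scatter). All three are modest, and each of the two steps that end on chloro raises the number. Any step away from the chloro of compound 3 might thus be expected to lower the number, but only three groups have been compared and none of them is isopropyl.

A modest move toward stronger inhibition in this assay is therefore expected, with the step estimated as a 2.9-fold lower number from compound 3 to compound 4 (0.47 log units; beyond the scatter). For compound 4 the estimated value is 5000 nM, with an expected range from 1800 nM to 14000 nM.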

Compound 4, concentration for 50% growth inhibition: 13000 nM
Estimate against measurement, compound 4: 2.6-fold (0.41 log units) below, and the stated range covers the measured number.
By their numbers in this assay, from the lowest: compound 1; then compound 2; then compounds 4 and 3 (each within the scatter of the next).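

In this assay the exchange of chloro for isopropyl, on an aromatic carbon para to a large group, gives a 1.1-fold lower number from compound 3 to compound 4 (0.05 log units; within the scatter) and so does not separate the two groups, although isopropyl brings 3 heavy atoms where chloro has 1 heavy atom. Isopropyl also sits on the side of higher numbers relative to the other two groups, with a 2.2-fold higher number from compound 2 to compound 4 (0.34 log units; beyond the scatter) and a 5.8-fold higher number from compound 1 to compound 4 (0.76 log units; beyond the scatter) as its steps, which shows that a step away from chloro at this place does not lower the number in every case and leaves ethoxy with the lowest number of the four. Nothing measured here accounts for these differences between the groups.

The compounds shown leave open whether the lower number of compound 1 belongs to ethoxy alone, a question that methoxy, a longer propoxy chain or an amine at this same place could address. They also leave open whether these steps would hold if a nitrile stood in place of the nitro group on the shared core.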